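Compound 2 to Compound 3: A Change at the Assay Limit

A few compounds are considered here, and "the series" means these few. Any claim that something is new, unique, unknown or untested is made for them only; others in the source may bear on it.

Measured compounds:
Compound 1, `N#CC1=C(N)Oc2c(c3nc4ccccc4nc3c3ccccc23)C12C(=O)N(Cc1cnnn1-c1ccc(F)c(Cl)c1)c1ccccc12`, gives > 50000 nM in this assay, a limit rather than a number.
Compound 2, `CCc1ccccc1-n1nncc1CN1C(=O)C2(C(C#N)=C(N)Oc3c(N)cc4nc5ccccc5nc4c32)c2ccccc21`, gives > 50000 nM, again a limit rather than a number.

Both compounds were tested in an ADME assay on HUVEC cells (Homo sapiens) for antiproliferative activity, read by MTT assay, with a stated time of 48 h; a higher number here means a weaker inhibitor, a lower number a stronger inhibitor. For compound 2 the result is only a limit; no measured number places it anywhere within the range of the assay. The same is true of the other value shown, so compound 2 stands at the limit together with compound 1, as summarised in the limit of > 50000 nM in this assay, at which 2 of the 2 values shown sit. Going by the values given here, no step between measured compounds can be drawn from these two results.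

Compound 3, `Cc1ccc(-n2nncc2CN2C(=O)C3(C(C#N)=C(N)Oc4c(N)cc5nc6ccccc6nc5c43)c3ccccc32)cc1Cl`, has not yet been measured. It differs from compound 2 by 3-chloro-4-methylphenyl in place of 2-ethylphenyl on an aromatic nitrogen. The rest of the shared core is unchanged.

Among the compounds with values here, with no measured step to lean on, the account expects no step beyond the usual scatter from compound 2 to compound 3, that is an expected step that the limit leaves unreadable from compound 2 to compound 3, and the result for compound 3 is most likely to be a limit again. The estimate for compound 3 is 60000 nM, with a range from 15000 nM to 250000 nM.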

Compound 3, half-maximal inhibitory concentration: > 50000 nM
Compound 3 gave a limit, no number; the forecaster's own chance of this, stated with the estimate: 80%; the middle value does not contradict the limit.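

In this assay compound 3 gives > 50000 nM, a limit and not a number. Compound 2 and compound 3 both stand at a limit, so no step between them can be read: the limit of > 50000 nM in this assay, at which 3 of the 3 values shown sit.

The compounds shown leave open whether any change to the group on the aromatic nitrogen would give a measured number in this assay.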